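The source may report more compounds than this note shows. Statements on the series, on what has been measured and on what is new or still open speak of the compounds shown alone.

Measured so far in an ADME assay on MT4 cells (Homo sapiens) for inhibition, read by MTT assay, with a stated time of 5 days; on this read-out lower numbers stand for higher toxicity in this test and higher numbers for lower toxicity in this test:
- compound 1 `Cc1cc(C)c(Oc2cc(Nc3ccc(C#N)cc3)ncc2[N+](=O)[O-])c(C)c1`: 69900 nM
- compound 2 `Cc1cc(C#N)cc(C)c1Oc1cc(Nc2ccc(C#N)cc2)ncc1[N+](=O)[O-]`: 36100 nM
- compound 3 `COc1cccc(OC)c1Oc1cc(Nc2ccc(C#N)cc2)ncc1[N+](=O)[O-]`: 319000 nM

Compound 1 lies within the scatter of compound 2, and the number for compound 3 is clearly higher than both. Compound 4 `N#Cc1ccc(Nc2cc(Oc3c(Cl)cccc3Cl)c([N+](=O)[O-])cn2)cc1` keeps the core of compound 1 and changes one group: 2,6-dichlorophenyl in place of 2,4,6-trimethylphenyl on an oxygen on an aromatic ring. For the measured compounds named here, the only measured step, a 1.9-fold lower number from compound 1 to compound 2 (0.29 log units; within the scatter), put cyano in place of methyl on an aromatic carbon, so it bears on this change only indirectly. No measured step exchanges the whole group, but compound 3, at 319000 nM, shows that higher numbers occur among these compounds. No step beyond the scatter is therefore expected in this assay, and the estimated change is a 1.2-fold lower number from compound 1 to compound 4 (0.07 log units; within the scatter). For compound 4 the estimated value is 60000 nM, with an expected range of 20000 nM to 200000 nM.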

Compound 4, half-maximal cytotoxic concentration: 27700 nM
Beside the measured number, compound 4's estimate is 2.2-fold (0.34 log units) above it, within the range that was stated.
By their numbers in this assay, from the lowest: compounds 4, 2 and 1 (each within the scatter of the next, the first and the last beyond it); then compound 3.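

In this assay the exchange of the whole group on the oxygen registers: 2,6-dichlorophenyl in place of 2,4,6-trimethylphenyl gives (a 2.5-fold lower number from compound 1 to compound 4 (0.40 log units; beyond the scatter)), a modest step. Unlike the cyano for methyl exchange, it lies beyond the scatter, so this position can shift the number toward higher toxicity in this test. Nothing available here explains the shift. As far as these compounds go, whether the two chlorine atoms, or the loss of the methyl groups, carry the step remains open. So does how the number would respond to an amine or a carboxylic acid on this ring.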